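Dropping the outer ring from a rhodanine-type compound

The source may hold more compounds than are shown below. What is called first, only, known or untested is meant among the compounds shown, and "the series" means these compounds.

Compound 2 `COc1ccccc1COc1ccccc1/C=C/C=C1\SC(=S)NC1=O` stands at the top of three measured compounds. In an assay on isolated protein for inhibition of protein tyrosine phosphatase type IVA 3 (Homo sapiens), tested at 5 ug/mL (on this read-out lower numbers stand for less inhibition and higher numbers for more inhibition at the one concentration tested (going by the name of the read-out)), compound 2 gives 78.8%, compound 1 `O=C1NC(=S)S/C1=C\C=C\c1ccccc1OCc1ccccc1C(F)(F)F` gives 40.8% and compound 3 `O=C1NC(=O)/C(=C/C=C/c2ccccc2OCc2ccccc2Br)S1` gives 22.5%. Compound 4 `COc1ccccc1/C=C/C=C1\SC(=S)NC1=O` is compound 2 with one change: hydrogen in place of 2-methoxyphenyl on a saturated chain carbon bound to an oxygen on an aromatic ring. Among the compounds with values here, the only measured step that touches this region is the one on the departing ring, a number 38 percentage points higher from compound 1 to compound 2 (beyond the scatter), which shows that what sits on that ring matters a great deal. Within the data shown here, removing the ring entirely is a larger change with no direct precedent here, so the direction is uncertain and a loss is judged somewhat more likely than a gain. Compound 4 is therefore expected at 45%, within 15% to 75%, an expected step of a number 33.8 percentage points lower from compound 2 to compound 4 (beyond the scatter).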

Compound 4, a percentage reported as inhibition, at one concentration (the size of the read-out at that concentration, not a potency): 41.7%
Compound 4: the middle estimate sits 3.3 percentage points above what was measured; measured number inside the range.
By their numbers in this assay, from the lowest: compound 3; then compounds 1 and 4 (each within the scatter of the next); then compound 2.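

Replacing the 2-methoxyphenyl with hydrogen gives a number 37.1 percentage points lower from compound 2 to compound 4 (beyond the scatter) in this assay and shows that the ring itself counts, not only what it carries. Within the data shown here, the earlier step showed only that a group on this ring matters. No measurement here gives the reason for this drop.

From the compounds shown here alone, it remains open whether a simple chain, such as a butyl chain, could stand in for the departed ring at this place. Going by these compounds, it is also open how an amine or a carboxylic acid on that ring would read.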